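Dropping the Chlorine: From Compound 1 to Compound 4

This account rests on a few compounds, and the source may have more. Where it says the series, first, only, none or still open, it means among the compounds named here.

Compound 1 `CNC(=O)c1cc(C(=O)N[C@H]2CC[C@H](O)CC2)c([C@@H](C)c2cccc(Cl)c2)o1` was tested in an ADME assay on cells (Hepatocyte, Canis lupus familiaris) for metabolic stability, read by LC-MS (a lower number here means slower removal, a higher number faster removal of the compound), where compound 1 gives 0.71 mL/min. Among the results that are full numbers, compound 1 stands lowest; compound 2 `CNC(=O)c1cc(C(=O)N[C@H]2[C@@H]3C[C@H](O)C[C@@H]32)n([C@@H](C)c2cccc(Cl)c2)n1` gives 8.3 mL/min, a gap well beyond the usual scatter. Compound 3 `CNC(=O)c1cc(C(=O)N[C@H]2CC[C@H](O)CC2)n([C@@H](C)c2ccccc2)n1` carries a different core, and in this assay compound 3 gives < 0.7 mL/min, which is a limit of the assay rather than a number (the limit of < 0.7 mL/min in this assay, at which 1 of the 3 values shown sits). Compound 4 `CNC(=O)c1cc(C(=O)N[C@H]2CC[C@H](O)CC2)c([C@@H](C)c2ccccc2)o1` differs from compound 1 by a single change: hydrogen in place of chloro on an aromatic carbon. Among the measured compounds shown here, no measured pair here shows this change on its own, so only a small step, within the scatter, is expected. The estimated step of a 1.4-fold lower number from compound 1 to compound 4 (0.15 log units; within the scatter) leads to an expected value for compound 4 of 0.5 mL/min, in a likely range from 0.3 mL/min to 1 mL/min.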

Compound 4, intrinsic clearance in a liver preparation (reported as CLH), per the amount of preparation that the assay uses in the Hepatocyte assay: < 0.7 mL/min
Compound 4: no number, only a limit; the forecaster's own chance of this, stated with the estimate: 50%; the middle value does not contradict the limit.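

In the Hepatocyte assay the new result is a limit of the assay and not a number, so removing the chloro reads only as an at least 1.0-fold lower number from compound 1 to compound 4 (0.00 log units; that floor lies within the scatter). In a physicochemical assay for solubility, read by HPLC, in simulated intestinal fluid, with a stated time of 16 h, at pH 6.5 (a higher number here means a more soluble compound, a lower number a less soluble compound), compound 1 gives 408 ug/mL and compound 4 gives 827 ug/mL. So a measured effect of this change at this place on the ring appears in solubility: the measured solubility of compound 1, 408 ug/mL, and of compound 4, 827 ug/mL, a 2.0-fold higher number (0.31 log units; beyond the scatter)

Still open, from the compounds shown here alone, is the actual number behind the limit of compound 4. Also open, going by these compounds, is how a methoxy or a nitrile at the same aromatic carbon would compare with hydrogen and chloro.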